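A few compounds are considered here, and "the series" means these few. Any claim that something is new, unique, unknown or untested is made for them only; others in the source may bear on it.

Working notes on the crown-ether esters.

Compound 1 `O=C(CCCCCc1ccccc1)OCC1COCCOCCOCCOCCOCCO1` carries a chain closed by phenyl; in a functional assay on HeLa cells (Homo sapiens) for inhibition, read by sulforhodamine B assay, with a stated time of 48 h (on this read-out higher numbers stand for weaker inhibition of growth and lower numbers for stronger inhibition of growth), compound 1 gives 79000 nM. Among the three measured members this is the highest number. Among the measured compounds shown here, the nearest is compound 3 `O=C(CCCCCCCCCCOc1ccccc1)OCC1COCCOCCOCCOCCOCCO1`, which in this assay gives 41000 nM; the single step between them, a 1.9-fold lower number from compound 1 to compound 3 (0.28 log units; within the scatter), is within the scatter. For the measured compounds named here, the furthest is compound 2 `O=C(OCC1COCCOCCOCCOCCOCCO1)c1cccc(-c2ccc(Br)cc2)c1`, an aromatic ester that in this assay gives 7800 nM; no one-place step links compound 2 to compound 1, so the two values are simply set side by side.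

Compound 4 `O=C(CCCCc1ccccc1)OCC1COCCOCCOCCOCCOCCO1` is not yet measured. Its difference from compound 1 is phenyl in place of benzyl on a saturated chain carbon, four bonds along the chain from a carbonyl carbon. Going by the values given here, the only measured step that alters the chain end, the one from compound 1 to compound 3, stayed within the scatter, and no measured pair shows this exact shortening. The step of a 1.1-fold lower number from compound 1 to compound 4 (0.05 log units; within the scatter) is therefore expected to be no larger than the scatter. For compound 4 in this assay the estimate is 70000 nM, with a range of 30000 nM to 160000 nM.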

Compound 4, concentration for 50% growth inhibition: 52000 nM
Beside the measured number, compound 4's estimate is 1.3-fold (0.13 log units) above it, within the range that was stated.
By their numbers in this assay, from the lowest: compound 2; then compounds 3, 4 and 1 (each within the scatter of the next).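

Among the compounds shown here, the replacement of benzyl by phenyl on a saturated chain carbon, four bonds along the chain from a carbonyl carbon, gives a 1.5-fold lower number from compound 1 to compound 4 (0.18 log units; within the scatter) in this assay and is the first direct reading of a chain shortening at this position. With the step of a 1.9-fold lower number from compound 1 to compound 3 (0.28 log units; within the scatter) also printed as within the scatter, neither of the two chain-end changes read so far separates from compound 1 in this assay's numbers. Nothing at hand bears on what lies behind this step.

Open, going by these compounds, is whether an amine or a carboxylic acid at the chain end, or a much shorter chain, would give a step beyond the scatter. For the compounds shown here, also open is how compound 2 relates to the chain esters, as no one-place step joins it to them.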